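This account rests on a few compounds, and the source may have more. Where it says the series, first, only, none or still open, it means among the compounds named here.

Measured so far in a functional assay on SK-HEP1 cells (Homo sapiens) for antiproliferative activity; on this read-out higher numbers stand for weaker inhibition of growth and lower numbers for stronger inhibition of growth:
- compound 1, `CO/N=C(/COc1c(-c2ccccc2)oc2ccccc2c1=O)c1ccc(F)cc1`, gives 13000000 nM
- compound 2, `CO/N=C(/COc1c(-c2ccccc2)oc2ccccc2c1=O)c1ccc(OC)cc1`, gives 11000000 nM
- compound 3, `CO/N=C(/COc1ccc2c(=O)cc(-c3ccccc3)oc2c1)c1ccc(F)cc1`, gives 3300000 nM

Compound 1 and compound 2 share a core and differ in one place: methoxy in place of fluoro on an aromatic carbon. That change gave a 1.2-fold lower number from compound 1 to compound 2 (0.07 log units; within the scatter), so the two values are indistinguishable. Compound 3 is built on a different core; the difference between the two cores is not broken down here. Compound 4, `CO/N=C(/COc1ccc2c(=O)cc(-c3ccccc3)oc2c1)c1ccc(OC)cc1`, is not yet measured and is related to compound 3 by the same change: methoxy in place of fluoro on an aromatic carbon. The step from compound 3 to compound 4 is expected to be about as small as the earlier one, a 1.2-fold lower number from compound 3 to compound 4 (0.07 log units; within the scatter), because the same change gave a 1.2-fold lower number from compound 1 to compound 2 (0.07 log units; within the scatter) on the other core. Compound 4 is therefore estimated at 2800000 nM in this assay.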

Compound 4, concentration for 50% growth inhibition: 4800000 nM
Compound 4: the middle estimate sits 1.7-fold (0.23 log units) below what was measured; low and high end bracket the measured number.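

In this assay, methoxy in place of fluoro gave a 1.5-fold higher number from compound 3 to compound 4 (0.16 log units; within the scatter), so these two values cannot be told apart. The change therefore looks the same on both cores, with no detectable effect on either: the same change on two cores in this assay, a 1.2-fold lower number (0.07 log units; within the scatter) from compound 1 to compound 2 and a 1.5-fold higher number (0.16 log units; within the scatter) from compound 3 to compound 4, 1.7-fold (0.24 log units) apart, within the scatter of two such steps. This shows only that 4-fluorophenyl to 4-methoxyphenyl made no measurable difference on these two cores in this assay; it does not show that a change with a large effect would carry from one core to the other, or that this change would stay as small on a third core.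

The compounds shown leave open whether an amine or a carboxylic acid in place of the fluoro would move the number beyond the scatter. They also leave open whether such a step would match on both cores.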